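Moving the fluorine on a benzyl arm, across two cores

The source may hold more compounds than are shown below. What is called first, only, known or untested is meant among the compounds shown, and "the series" means these compounds.

Compound 1 `COc1ccc(/C=C2\CN(C(=S)SCc3cn(Cc4ccccc4F)nn3)C/C(=C\c3ccc(OC)cc3)C2=O)cc1` and compound 2 `COc1ccc(/C=C2\CN(C(=S)SCc3cn(Cc4ccc(F)cc4)nn3)C/C(=C\c3ccc(OC)cc3)C2=O)cc1` share one core and differ only in that (4-fluorophenyl in place of 2-fluorophenyl on a saturated chain carbon bound to an aromatic nitrogen). In a functional assay on MCF7 cells (Homo sapiens) for cytotoxicity, read by MTT assay, with a stated time of 24 h (a higher number here means a weaker inhibitor, a lower number a stronger inhibitor), compound 1 gives 79400 nM. Compound 2 reaches only the limit of the assay, > 100000 nM. The change thus gave an at least 1.2-fold higher number from compound 1 to compound 2 (0.10 log units; that floor lies within the scatter), a step whose floor is set by the limit of > 100000 nM in this assay, at which 1 of the 3 values shown sits. Compound 3 `O=C1/C(=C/c2ccccc2F)CN(C(=S)SCc2cn(Cc3ccccc3F)nn2)C/C1=C\c1ccccc1F` is built on a different core; how its core differs from that of compound 1 is not broken down here. In this assay compound 3 gives 51600 nM, and this value and that of compound 1 lie within the scatter of one another. Compound 4 `O=C1/C(=C/c2ccccc2F)CN(C(=S)SCc2cn(Cc3ccc(F)cc3)nn2)C/C1=C\c1ccccc1F` has not yet been measured; it differs from compound 3 by the same kind of change, (4-fluorophenyl in place of 2-fluorophenyl on a saturated chain carbon bound to an aromatic nitrogen). Because the same change gave an at least 1.2-fold higher number from compound 1 to compound 2 (0.10 log units; that floor lies within the scatter), a similarly small step is expected here, a 1.5-fold higher number from compound 3 to compound 4 (0.16 log units; within the scatter). Compound 4 is therefore estimated at 75000 nM in this assay, likely between 38000 nM and 150000 nM, with a fair chance that the assay again reports only a limit.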

Compound 4, half-maximal inhibitory concentration: 56900 nM
Compound 4: middle estimate off by 1.3-fold (0.12 log units), on the high side; the range from low to high includes it.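

On the core of compound 3, the change from 2-fluorobenzyl to 4-fluorobenzyl gave a 1.1-fold higher number from compound 3 to compound 4 (0.04 log units; within the scatter) in this assay, so on this core the swap of fluorine site leaves the two values within the scatter of each other. The value of compound 2, > 100000 nM, is a limit of the assay and not a number. Set side by side, the two steps show no shift beyond the scatter on the core of compound 3, but they do not show that the change behaves in the same way on both cores: the same change on two cores in this assay, an at least 1.2-fold higher number (0.10 log units; that floor lies within the scatter) from compound 1 to compound 2 and a 1.1-fold higher number (0.04 log units; within the scatter) from compound 3 to compound 4; the limit leaves it open whether they differ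

All four compounds carry a fluorobenzyl arm on the triazole-bearing side, which leaves open how a plain benzyl, a chlorobenzyl or a benzyl carrying an amine or a carboxylic acid would read in this assay. From the compounds shown here alone, how these compounds behave in any other cell line also stays open.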